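A few compounds are considered here, and "the series" means these few. Any claim that something is new, unique, unknown or untested is made for them only; others in the source may bear on it.

Of the compounds shown here, three built on one shared core have been measured in a functional assay on HGC-27 cells (Homo sapiens) for inhibition, read by MTT assay, with a stated time of 72 h; a higher number here means a weaker inhibitor, a lower number a stronger inhibitor. Compound 1 `Cc1cc(N2CC[C@@H](C)[C@@H](N(C)c3ncnc4[nH]ccc34)C2)n2nc(SCc3ccccc3)nc2n1` gives 13900 nM in this assay. Compound 3 `Cc1cc(N2CC[C@@H](C)[C@@H](N(C)c3ncnc4[nH]ccc34)C2)n2nc(SCC3CCCCC3)nc2n1` gives 11500 nM in this assay, and the step of a 1.2-fold lower number from compound 1 to compound 3 (0.08 log units; within the scatter) lies within the scatter. Compound 2 `Cc1cc(N2CC[C@@H](C)[C@@H](N(C)c3ncnc4[nH]ccc34)C2)n2nc(SCc3csc4ccc(Cl)cc34)nc2n1` reaches only the limit of this assay, > 100000 nM. Compound 2 therefore stands as the weakest of the three, with an at least 7.1-fold higher number from compound 1 to compound 2 (0.85 log units; beyond the scatter) and an at least 8.6-fold lower number from compound 2 to compound 3 (0.93 log units; beyond the scatter). Compound 4 `CCCSc1nc2nc(C)cc(N3CC[C@@H](C)[C@@H](N(C)c4ncnc5[nH]ccc45)C3)n2n1` differs from compound 2 by ethyl in place of 5-chloro-1-benzothiophen-3-yl on a saturated chain carbon bound to a sulfur. Both measured steps that remove the 5-chloro-1-benzothiophen-3-yl group bear on this change and were at least modest, so a lower number is expected for compound 4, roughly back to where compound 1 and compound 3 sit. Compound 4 is estimated at 15000 nM, between 6000 nM and 45000 nM, an expected step of an at least 6.6-fold lower number from compound 2 to compound 4 (0.82 log units; beyond the scatter).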

Compound 4, half-maximal inhibitory concentration: 20900 nM
The estimate for compound 4 lay 1.4-fold (0.14 log units) below the measured number; low and high end bracket the measured number.
By their numbers in this assay, from the lowest: compounds 3, 1 and 4 (each within the scatter of the next). At a limit, above all of these: compound 2.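

In this assay, an ethyl group with no ring, on a saturated chain carbon bound to a sulfur, is not separated from phenyl, a 1.5-fold higher number from compound 1 to compound 4 (0.18 log units; within the scatter), or from cyclohexyl, a 1.8-fold higher number from compound 3 to compound 4 (0.26 log units; within the scatter), so a ring at this place is not needed to keep these numbers. Only 5-chloro-1-benzothiophen-3-yl stands apart, an at least 4.7-fold lower number from compound 2 to compound 4 (0.67 log units; beyond the scatter). Compound 2 is held at a limit, so this step has no upper bound: the limit of > 100000 nM in this assay, at which 1 of the 4 values shown sits.

As far as these compounds go, whether the chlorine or the fused ring system sets compound 2 apart remains open. So does the effect of a longer chain or of an amine or carboxylic acid at this place.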